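The compounds below may be only part of what the source reports. "The series", "measured", "known", "first", "only" and "open" are said of these compounds alone.

Measured compounds in an ADME assay on PBMC cells (Homo sapiens) for cytotoxicity, with a stated time of 5 days; on this read-out higher numbers stand for weaker inhibition and lower numbers for stronger inhibition:
Compound 1 `COc1nc(Cl)nc2c1ncn2[C@H]1C[C@H](N=[N+]=[N-])[C@@H](CO)O1` gives > 100000 nM in this assay, which is a limit of the assay and not a number.
Compound 2 `C#CCNc1nc(N)nc2c1ncn2[C@H]1C[C@H](N=[N+]=[N-])[C@@H](CO)O1` gives > 100000 nM in this assay, again only a limit.
Compound 3 `COc1nc(OC)c2ncn([C@H]3C[C@H](N=[N+]=[N-])[C@@H](CO)O3)c2n1` gives > 100000 nM in this assay, again only a limit.

Compound 2 thus stands where every measured value stands: at the limit of > 100000 nM in this assay, at which 3 of the 3 values shown sit. No number places it higher or lower than compound 1 or compound 3.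

Compound 4 `CC(CO)Nc1nc(N)nc2c1ncn2[C@H]1C[C@H](N=[N+]=[N-])[C@@H](CO)O1` differs from compound 2 by 1-(hydroxymethyl)ethyl in place of propargyl on a nitrogen on an aromatic ring.

Going by the values given here, the only step between measured compounds is a step that the two limits leave unreadable from compound 1 to compound 3, a change on an aromatic carbon of the shared core, and both of its ends are limits, so its size is not readable. Among the compounds with values here, no measured step touches the nitrogen on the aromatic ring where compound 4 changes, so nothing measured bears directly on this exchange.

Within the data shown here, with every compound so far at the limit, compound 4 is expected to remain there as well, with no step in this assay readable beyond the scatter. Compound 4 is therefore estimated at 200000 nM, with a range from 100000 nM to 1000000 nM. The estimated step is a step that the limit leaves unreadable from compound 2 to compound 4.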

Compound 4, half-maximal inhibitory concentration: > 100000 nM
Compound 4: no number, only a limit (the forecaster's own chance of this, stated with the estimate: 90%); the middle value does not contradict the limit.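

Going by these compounds alone, compound 2 and compound 4 both give only a limit and not a number in this assay, so no step between them can be read. The compounds shown leave open whether any change on the shared core shifts this read-out, for all share one position: the limit of > 100000 nM in this assay, at which 4 of the 4 values shown sit.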